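Trimming the sulfonyl substituent and expecting little change

The compounds below may be only part of what the source reports. "The series", "measured", "known", "first", "only" and "open" are said of these compounds alone.

Measured in an ADME assay on microsomes from liver (Homo sapiens) for metabolic stability, with a stated time of 10 min (a higher number here means that more of the compound is left, a lower number that less of the compound is left), so far:
Compound 1 `O=C(NS(=O)(=O)c1ccccc1)c1ccc(Nc2nc(NC3(c4ccc(Cl)cc4)CC3)nc(OCC(F)(F)F)n2)cc1` gives 100%.
Compound 2 `O=C(NS(=O)(=O)CCNC(=O)C1CC1)c1ccc(Nc2nc(NC3(c4ccc(Cl)cc4)CC3)nc(OCC(F)(F)F)n2)cc1` gives 90%.

Going by the values given here, compound 2 stands close to compound 1 in this assay: the only measured step, a number 10 percentage points lower from compound 1 to compound 2 (within the scatter), stays within the usual scatter. Compound 3 `O=C(NS(=O)(=O)C1CC1)c1ccc(Nc2nc(NC3(c4ccc(Cl)cc4)CC3)nc(OCC(F)(F)F)n2)cc1` differs from compound 2 by cyclopropyl in place of 2-((cyclopropylcarbonyl)amino)ethyl on a sulfonyl sulfur. Among the compounds with values here, the one step that bears on this, also a change of the group on the sulfonyl sulfur, was small, so no step beyond the scatter is expected in this assay; the expected step is no change at the digits printed from compound 2 to compound 3 (within the scatter). Compound 3 is therefore estimated at 90%, with a range from 70% to 100%.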

Compound 3, percent of the compound remaining: 100%
Compound 3: middle estimate off by 10 percentage points, on the low side; low and high end bracket the measured number.
By their numbers in this assay, from the lowest: compounds 2, 1 and 3 (each within the scatter of the next).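

In this assay, swapping the group on the sulfonyl sulfur for cyclopropyl gives a number 10 percentage points higher from compound 2 to compound 3 (within the scatter) and no change at the digits printed from compound 1 to compound 3 (within the scatter). Phenyl, 2-((cyclopropylcarbonyl)amino)ethyl and cyclopropyl therefore cannot be told apart at this position in this assay, even though cyclopropyl lacks the hydrogen-bond donor and acceptor of the chain. No available evidence bears on the reason for this.

Still open, from the compounds shown here alone, is whether an amine or a carboxylic acid on the sulfonyl sulfur would leave the read-out just as unchanged. The same question stands for a longer chain of carbon only.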